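The compounds below may be only part of what the source reports. "The series", "measured", "known", "first", "only" and "open" are said of these compounds alone.

Measured compounds in a functional assay on MOLT-4 cells (Homo sapiens); on this read-out higher numbers stand for weaker inhibition and lower numbers for stronger inhibition:
- compound 1 `Nc1ncnc2c1ncn2C[C@@H]1C[C@H](CO)c2ccccc21`: 24 ug/mL
- compound 2 `Cn1ncc2c1[C@H](Cn1cnc3c(Cl)ncnc31)C[C@@H]2CO[Si](c1ccccc1)(c1ccccc1)C(C)(C)C`: 3.2 ug/mL
- compound 3 `OC[C@H]1C[C@@H](Cn2cnc3c(-c4ccc(Cl)cc4)ncnc32)c2ccccc21`: 0.63 ug/mL

Compound 1 gives the highest number of the three in this assay. Compound 2 sits nearer to it, with a lower value, while compound 3 lies furthest away: a 38-fold lower number from compound 1 to compound 3 (1.58 log units; beyond the scatter).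

Compound 4 `CC(C)Nc1ncnc2c1ncn2C[C@@H]1C[C@H](CO)c2ccccc21` differs from compound 1 by isopropyl in place of hydrogen on a nitrogen on an aromatic ring. The only measured single-place step in the set, from compound 1 to compound 3, concerns a different change on an aromatic carbon and does not touch the amino nitrogen, so no step shown here bears directly on the alkylation of that nitrogen. Compound 2 carries a chloro group at the corresponding position and is not a single-place comparison either. Among the measured compounds shown here, with no direct precedent, the expected step from compound 1 to compound 4 is a 2.0-fold lower number from compound 1 to compound 4 (0.30 log units; within the scatter), modest and not confidently beyond the scatter, with a slight lean toward a lower number. For compound 4 the estimated value in this assay is 12 ug/mL, with a range from 4 ug/mL to 40 ug/mL.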

Compound 4, half-maximal inhibitory concentration: 24 ug/mL
Compound 4: middle estimate off by 2.0-fold (0.30 log units), on the low side; the measured number falls inside the stated range.
By their numbers in this assay, from the lowest: compound 3; then compound 2; then compounds 1 and 4 (each within the scatter of the next).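

In this assay, isopropyl in place of hydrogen on a nitrogen on an aromatic ring leaves the read-out unmoved (no change at the digits printed from compound 1 to compound 4 (within the scatter)), so this substituent gives no separation from the parent amine. Among the compounds shown here, the change on the aromatic carbon remains the one that separates compounds here (a 38-fold higher number from compound 3 to compound 4 (1.58 log units; beyond the scatter)): isopropylamino gives no improvement over amino, and only 4-chlorophenyl has reached the low end of the range. No supporting data bear on why either step has its size.

On these data alone, whether the flat result holds for other groups on that nitrogen, such as cyclopentyl or benzyl, remains open. Also open, as far as these compounds go, is whether an unsubstituted phenyl on the aromatic carbon would match compound 3 at 0.63 ug/mL.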